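The source may hold more compounds than are shown below. What is called first, only, known or untested is meant among the compounds shown, and "the series" means these compounds.

Values in a functional assay on HT-29 cells (Homo sapiens) for inhibition, read by MTT assay, with a stated time of 48 h; a higher number here means a weaker inhibitor, a lower number a stronger inhibitor:
- compound 1 `COc1ccc(-n2c(S)nnc2-c2cc(OC)c(OC)c(OC)c2)cc1`: > 60000 nM (a limit of the assay, not a number)
- compound 2 `COc1ccc(-n2c(SCC(=O)c3ccccc3)nnc2-c2cc(OC)c(OC)c(OC)c2)cc1`: > 60000 nM (a limit of the assay, not a number)
- compound 3 `COc1cc(-c2nnc(SCC(=O)c3ccccc3)n2-c2ccc(N(C)C)cc2)cc(OC)c1OC`: 45200 nM

Within the data shown here, compound 3 at 45200 nM holds the only true number. The other two entries are limits.

Next is compound 4 `COc1ccc(NC(=O)CSc2nnc(-c3cc(OC)c(OC)c(OC)c3)n2-c2ccc(N(C)C)cc2)cc1`, which is not yet measured. It carries (4-methoxyphenyl)amino in place of phenyl on a carbonyl carbon. The same difference reads as benzoylmethyl to ((4-methoxyphenyl)carbamoyl)methyl.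

Among the measured compounds shown here, two measured steps bear on this only loosely. For the measured compounds named here, the first is a step that the two limits leave unreadable from compound 1 to compound 2; it introduces the benzoylmethyl group now being altered, but gives no size. The second is an at least 1.3-fold lower number from compound 2 to compound 3 (0.12 log units; that floor lies within the scatter); it is a change at another place. Neither measures a change on a carbonyl carbon, so no direction follows from them.

In this assay, little room remains on the upper side of compound 3 at 45200 nM before the assay stops returning numbers. A lower number is therefore expected, though only tentatively, and a limit remains possible. The expected step is a 3.0-fold lower number from compound 3 to compound 4 (0.48 log units; beyond the scatter). For compound 4 the estimated value is 15000 nM, with an expected range of 1500 nM to 70000 nM.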

Compound 4, half-maximal inhibitory concentration: 51400 nM
Beside the measured number, compound 4's estimate is 3.4-fold (0.53 log units) below it; the range from low to high includes it.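

In this assay, among these compounds, the first measured change on this carbonyl carbon is a 1.1-fold higher number from compound 3 to compound 4 (0.06 log units; within the scatter). Exchanging benzoyl for (4-methoxyphenyl)carbamoyl therefore gives two values that this assay cannot tell apart, although the entering group has more heavy atoms than phenyl and carries a hydrogen-bond donor and a hydrogen-bond acceptor that phenyl lacks. On the evidence of this single pair, the position accepts the amide in place of the ketone with no step beyond the scatter, but both compounds read close to the point where the series stops returning numbers: the limit of > 60000 nM in this assay, at which 2 of the 4 values shown sit.

As far as these compounds go, whether any group on this carbonyl carbon can produce a step beyond the scatter remains open, as does whether the methoxy on the entering phenyl ring contributes anything, since the pair changes the amide link and that methoxy together. A plain phenylamino group, a morpholine or a carboxylic acid at this place would separate those contributions and would show whether this assay can resolve differences at this position.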